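The compounds below may be only part of what the source reports. "The series", "measured", "known", "first", "only" and "open" are said of these compounds alone.

In a functional assay on PC-3 cells (Homo sapiens) for antiproliferative activity, read by sulforhodamine B assay, with a stated time of 72 h (a lower number here means a stronger inhibitor, a higher number a weaker inhibitor), compound 1 `COc1ncc(-c2ccc3ncc(NCc4ccccc4)c(OC)c3c2)cc1NS(=O)(=O)c1ccc(F)cc1F` gives 4320 nM, while compound 2 `COc1ncc(-c2ccc3ncc(NCC4CCCCC4)c(OC)c3c2)cc1NS(=O)(=O)c1ccc(F)cc1F` gives 9000 nM, the higher of the two numbers and therefore the weaker result. Going by the values given here, the only measured step is a 2.1-fold higher number from compound 1 to compound 2 (0.32 log units; beyond the scatter). This modest step comes with cyclohexyl in place of phenyl on a saturated chain carbon bound to a nitrogen on an aromatic ring.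

The next compound, compound 3 `CCNc1cnc2ccc(-c3cnc(OC)c(NS(=O)(=O)c4ccc(F)cc4F)c3)cc2c1OC`, has not yet been measured. It differs from compound 2 as follows: methyl in place of cyclohexyl on a saturated chain carbon bound to a nitrogen on an aromatic ring. Cut one bond further out, the same difference reads cyclohexylmethyl to ethyl. The measured step bears on this only in part, since it exchanges one ring for another and does not show what happens when the ring is lost. Still, the change at this place in a 2.1-fold higher number from compound 1 to compound 2 (0.32 log units; beyond the scatter) was small, so a large jump is not expected. A modest move towards a lower number seems most likely, although the direction is uncertain. The expected change is a 2.3-fold lower number from compound 2 to compound 3 (0.35 log units; beyond the scatter). For compound 3, the estimated value is 4000 nM, with an expected range from 1200 nM to 12000 nM.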

Compound 3, half-maximal inhibitory concentration: 4820 nM
Compound 3: middle estimate off by 1.2-fold (0.08 log units), on the low side, within the range that was stated.
By their numbers in this assay, from the lowest: compounds 1, 3 and 2 (each within the scatter of the next, the first and the last beyond it).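

The result shows that, in this series, a ring on the chain carbon bound to the nitrogen is not required for activity in this assay. The earlier pair only exchanged one ring for another, whereas losing the ring altogether and placing methyl there gives a 1.9-fold lower number from compound 2 to compound 3 (0.27 log units; within the scatter) when it replaces cyclohexyl, and a 1.1-fold higher number from compound 1 to compound 3 (0.05 log units; within the scatter) when it replaces phenyl. Both steps lie within the scatter, so the small ethylamino group of compound 3 cannot be told apart from either larger group, even though compound 1 and compound 2 can be told apart from each other, and nothing available here explains this result.

These three compounds do not show whether a group at this place can bring a clearly lower number than compound 1 or compound 3 give, since all three sit close together. A terminal amine or a carboxylic acid on the chain, a longer chain such as butyl, or the bare amino group with no chain at all would each test this place in a way that phenyl, cyclohexyl and methyl do not.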